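The source may hold more compounds than are shown below. What is called first, only, known or untested is meant among the compounds shown, and "the series" means these compounds.

Compound 2 `Nc1nc(N)c(CCCNc2cc(F)c([N+](=O)[O-])cc2[N+](=O)[O-])c(O)n1` and compound 3 `Nc1nc(N)c(CCCN(Cc2ccc(NC(CCC(=O)O)C(=O)O)cc2)c2ccc([N+](=O)[O-])c(F)c2[N+](=O)[O-])c(O)n1` share a core, and the difference between the two cores is not broken down here. In a functional assay on CCRF-CEM cells (Homo sapiens) for cytotoxicity, in the absence of a further agent (on this read-out higher numbers stand for weaker inhibition and lower numbers for stronger inhibition), compound 2 gives 1100 nM, while compound 3 gives 48000 nM in this assay. Compound 1 `Nc1nc(N)c(CCCN(Cc2ccc(NC(CCC(=O)O)C(=O)O)cc2)c2ccc([N+](=O)[O-])c(F)c2F)c(O)n1` differs from compound 3 by fluoro in place of nitro on an aromatic carbon. For compound 1 this assay reports only a limit, > 100000 nM. The measured step is an at least 2.0-fold higher number from compound 3 to compound 1 (0.31 log units; beyond the scatter); because the limit of > 100000 nM in this assay, at which 1 of the 3 values shown sits, sits where the reported value ends, the true step may well be larger than the stated bound.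

Compound 4 `Nc1nc(N)c(CCCNc2cc(F)c(F)cc2[N+](=O)[O-])c(O)n1`, not yet measured, differs from compound 2 by fluoro in place of nitro on an aromatic carbon. For the measured compounds named here, this is the same kind of change as the one from compound 3 to compound 1, not the same one: in compound 3 the place is ortho to a large group, in compound 2 it is para to a large group.

For compound 4 a weakening step of a 4.5-fold higher number from compound 2 to compound 4 (0.66 log units; beyond the scatter) is expected in this assay, resting on the step of an at least 2.0-fold higher number from compound 3 to compound 1 (0.31 log units; beyond the scatter) and on the value of compound 2, 1100 nM. Compound 4 is therefore estimated at 5000 nM, most likely between 1500 nM and 30000 nM.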

Compound 4, half-maximal inhibitory concentration: > 100000 nM
Compound 4 was reported as a limit (the forecaster's own chance of this, stated with the estimate: 10%); at least 20-fold (1.30 log units) between middle value and limit.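

In this assay, fluoro in place of nitro on an aromatic carbon gives an at least 90-fold higher number from compound 2 to compound 4 (1.95 log units; beyond the scatter), a large step in the same direction as the one seen on the other core. Compound 4 is known only as a limit, > 100000 nM. The direction of the change therefore carries across the two cores shown, but its size does not transfer in any way that can be stated, and the estimate of one step from the other has no firm footing: the same change on two cores in this assay, an at least 2.0-fold higher number (0.31 log units; beyond the scatter) from compound 3 to compound 1 and an at least 90-fold higher number (1.95 log units; beyond the scatter) from compound 2 to compound 4; the limit leaves it open whether they differ

Open, on these data alone, is whether the loss follows from fluoro entering or from nitro leaving, which an amine or a nitrile at the same place on either core could begin to separate. Also open is how large the two steps really are, and that needs compounds with the same change whose values are not limits: the limit of > 100000 nM in this assay, at which 2 of the 4 values shown sit.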